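Aryl swap on a triazole nitrogen of a triterpenoid oxime

The compounds below may be only part of what the source reports. "The series", "measured", "known", "first", "only" and "open" are said of these compounds alone.

Measured so far:
compound 1 `CC(C)=CCC/C(C)=C/CC/C(C)=C/CC[C@@H]1[C@@]2(C)CCC(=O)C(C)(C)[C@@H]2CC[C@@]1(C)O` gives 13200 nM in a functional assay on DU-145 cells (Homo sapiens) for cytotoxicity, read by MTT assay, with a stated time of 48 h; a higher number here means a weaker inhibitor, a lower number a stronger inhibitor;
compound 2 `COc1cccc(-n2cc(CO/N=C3\CC[C@]4(C)[C@@H](CC/C=C(\C)CC/C=C(\C)CCC=C(C)C)[C@](C)(O)CC[C@H]4C3(C)C)nn2)c1` gives 30500 nM;
compound 3 `CC(C)=CCC/C(C)=C/CC/C(C)=C/CC[C@@H]1[C@@]2(C)CC/C(=N\OCc3cn(-c4ccccc4C#N)nn3)C(C)(C)[C@@H]2CC[C@@]1(C)O` gives 25100 nM.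

Compound 3 holds the second highest of the three numbers; its nearest neighbour is compound 2, and the gap to each neighbour is within the scatter, so no order among the three can be claimed. Compound 4 `CC(C)=CCC/C(C)=C/CC/C(C)=C/CC[C@@H]1[C@@]2(C)CC/C(=N\OCc3cn(-c4c(Cl)cc([N+](=O)[O-])cc4Cl)nn3)C(C)(C)[C@@H]2CC[C@@]1(C)O` differs from compound 3 in one place: 2,6-dichloro-4-nitrophenyl in place of 2-cyanophenyl on an aromatic nitrogen. Among the compounds with values here, the only step that bears on this change is the aryl exchange a 1.2-fold lower number from compound 2 to compound 3 (0.08 log units; within the scatter), which lay within the scatter. The same kind of exchange is therefore expected to give no step beyond the scatter, a 1.1-fold higher number from compound 3 to compound 4 (0.03 log units; within the scatter). For compound 4 the estimate is 27000 nM, between 10000 nM and 70000 nM.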

Compound 4, half-maximal inhibitory concentration: 16400 nM
Compound 4: middle estimate off by 1.6-fold (0.22 log units), on the high side, within the range that was stated.
By their numbers in this assay, from the lowest: compounds 1, 4, 3 and 2 (each within the scatter of the next, the first and the last beyond it).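

In this assay a third aryl group on this aromatic nitrogen, the larger 2,6-dichloro-4-nitrophenyl, again leaves the number within the scatter, with a 1.5-fold lower number from compound 3 to compound 4 (0.18 log units; within the scatter) and with a 1.9-fold lower number from compound 2 to compound 4 (0.27 log units; within the scatter). Across these three aryl groups, this position has so far shown no step beyond the scatter, even with chlorine and a nitro group entering. No measurement available here offers a reason for this result. From the compounds shown here alone, whether a simple alkyl chain in place of the aryl group, or an aryl group carrying an amine or a carboxylic acid, would give a larger step remains open.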